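Chloro for Fluoro on a Second Core

The source may report more compounds than this note shows. Statements on the series, on what has been measured and on what is new or still open speak of the compounds shown alone.

Compound 1 `COc1cc(C#N)ccc1OCc1nnc(-c2ccc(F)cc2)o1` and compound 2 `COc1cc(C#N)ccc1OCc1nnc(-c2ccc(Cl)cc2)o1` share one core; compound 3 `N#Cc1ccc(OCc2nnc(-c3ccc(F)cc3)o2)cc1F` and compound 4 `N#Cc1ccc(OCc2nnc(-c3ccc(Cl)cc3)o2)cc1F` share another, and the difference between the two cores is not broken down here. In an ADME assay on MCF-10A cells (Homo sapiens) for cytotoxicity, read by MTT assay, with a stated time of 48 h (on this read-out lower numbers stand for stronger inhibition and higher numbers for weaker inhibition), compound 1 gives only a limit, > 100000 nM (the limit of > 100000 nM in this assay, at which 1 of the 3 values shown sits). In this assay compound 2 gives 89500 nM, so the change chloro in place of fluoro on an aromatic carbon made a step of an at least 1.1-fold lower number from compound 1 to compound 2 (0.04 log units; that floor lies within the scatter). In this assay compound 3 gives 84200 nM. Compound 4 carries the same change on the second core, (chloro in place of fluoro on an aromatic carbon). From compound 3 to compound 4 a step of a 1.2-fold lower number from compound 3 to compound 4 (0.08 log units; within the scatter) is expected, resting on the measured step of an at least 1.1-fold lower number from compound 1 to compound 2 (0.04 log units; that floor lies within the scatter). Compound 4 is therefore estimated at 70000 nM in this assay, between 40000 nM and 110000 nM.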

Compound 4, half-maximal inhibitory concentration: > 100000 nM
Compound 4 was reported as a limit; the forecaster's own chance of this, stated with the estimate: 20%; middle value at least 1.4-fold (0.15 log units) from the limit.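

In this assay compound 4 gives > 100000 nM, which is a limit of the assay and not a number. Chloro in place of fluoro on the second core therefore makes a step of an at least 1.1-fold higher number from compound 3 to compound 4 (0.07 log units; that floor lies within the scatter). Set beside the first core, this shows neither that the change carries over from one core to the other nor that it acts differently on each: the same change on two cores in this assay, an at least 1.1-fold lower number (0.04 log units; that floor lies within the scatter) from compound 1 to compound 2 and an at least 1.1-fold higher number (0.07 log units; that floor lies within the scatter) from compound 3 to compound 4; the limit leaves it open whether they differ.

Going by these compounds, the true size of both steps stays open: the limit of > 100000 nM in this assay, at which 2 of the 4 values shown sit. The compounds shown also leave open whether another group on the same aromatic carbon, such as bromo, methyl or an amine, would give a step that could be read fully on either core.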